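From thiophen-3-yl to 4-fluorophenyl in an antiproliferative series

This account rests on a few compounds, and the source may have more. Where it says the series, first, only, none or still open, it means among the compounds named here.

In a functional assay on L1210 cells (Mus musculus) for antiproliferative activity (on this read-out higher numbers stand for weaker inhibition and lower numbers for stronger inhibition), compound 2 `COc1cc(C(=O)c2sc(-c3ccsc3)cc2N)cc(OC)c1OC` gives 12 nM, the lower of the two numbers available, while compound 1 `COc1cc(C(=O)c2sc(-c3ccc(Br)cc3)cc2N)cc(OC)c1OC` gives 100 nM. Compound 3 `COc1cc(C(=O)c2sc(-c3ccc(F)cc3)cc2N)cc(OC)c1OC` has not yet been measured. It carries 4-fluorophenyl in place of thiophen-3-yl on an aromatic carbon, next to the ring sulfur: 4-fluorophenyl in place of thiophen-3-yl on an aromatic carbon. Within the data shown here, only one measured step bears on this change: an 8.3-fold lower number from compound 1 to compound 2 (0.92 log units; beyond the scatter), beyond the scatter, with thiophen-3-yl replacing 4-bromophenyl at the same place. Among the measured compounds shown here, compound 3 again bears a halogen-carrying phenyl group, so a higher number in this assay is expected, although no measured compound shows how fluorine compares with bromine here. The expected change is a 3.8-fold higher number from compound 2 to compound 3 (0.57 log units; beyond the scatter), somewhat smaller than the measured step. For compound 3 the estimated value is 45 nM, with an expected range from 15 nM to 130 nM.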

Compound 3, half-maximal inhibitory concentration: 20 nM
For compound 3 the middle estimate is 2.3-fold (0.35 log units) above the measured one; the range from low to high includes it.
By their numbers in this assay, from the lowest: compounds 2 and 3 (each within the scatter of the next); then compound 1.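

On this position, this assay does not separate a five-membered ring with sulfur from a six-membered aromatic ring of carbon only: 4-fluorophenyl in place of thiophen-3-yl gives a 1.7-fold higher number from compound 2 to compound 3 (0.22 log units; within the scatter) and the two cannot be told apart. The earlier gap therefore did not hold for phenyl groups as such, since fluoro in place of bromo alone gives a 5.0-fold lower number from compound 1 to compound 3 (0.70 log units; beyond the scatter) and leaves compound 1 as the one that stands apart from the other two. Nothing shown explains this difference between the two halogens.

The compounds shown leave open where a phenyl ring without a halogen, a 4-chlorophenyl group or a 4-methoxyphenyl group would fall at this position. They also leave open whether thiophen-2-yl or a saturated ring such as cyclohexyl would match thiophen-3-yl here.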